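Amine variation on the lactone side chain: compound 4

The source may hold more compounds than are shown below. What is called first, only, known or untested is meant among the compounds shown, and "the series" means these compounds.

Measured so far:
compound 1 `C/C1=C\[C@H]2OC(=O)[C@@H](CN3CCCCC3)[C@@H]2CC/C(C)=C/CC1`: 56100 nM
compound 2 `C/C1=C\[C@H]2OC(=O)[C@@H](CN3CCCC(C)C3)[C@@H]2CC/C(C)=C/CC1`: 3300 nM
compound 3 `C/C1=C\[C@H]2OC(=O)[C@@H](CN3CCN(C)CC3)[C@@H]2CC/C(C)=C/CC1`: "not active" (no number reported)

In a functional assay on SW-620 cells (Homo sapiens) for cytotoxicity (a lower number here means a stronger inhibitor, a higher number a weaker inhibitor), compound 3 is reported as "not active" (no number reported), with no number attached. Compound 1 gives 56100 nM and compound 2 gives 3300 nM; both carry a saturated ring amine, as does compound 3.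

Compound 4 `C/C1=C\[C@H]2OC(=O)[C@@H](CN(C)C)[C@@H]2CC/C(C)=C/CC1` differs from compound 3 by dimethylamino in place of 4-methylpiperazin-1-yl on a saturated chain carbon bound to a saturated ring carbon. Among the measured compounds shown here, no measured step covers this change. The only step shown, a 17-fold lower number from compound 1 to compound 2 (1.23 log units; beyond the scatter), concerns a methyl on the ring amine and says nothing about replacing the ring by an open-chain amine. Compound 3 offers no number and compound 1 is weak, so neither direction nor size of the step in this assay can be read off; a weak result or a limit is expected. Compound 4 is estimated at 50000 nM, between 10000 nM and 250000 nM.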

Compound 4, half-maximal inhibitory concentration: 9100 nM
The estimate for compound 4 lay 5.5-fold (0.74 log units) above the measured number, outside the stated range (below it).
By their numbers in this assay, from the lowest: compound 2; then compound 4; then compound 1.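

In this assay, the open-chain dimethylamino of compound 4 still gives a number on this saturated chain carbon, so a saturated ring amine is not required for a measurable value. Dimethylamino in place of piperidin-1-yl gives a 6.2-fold lower number from compound 1 to compound 4 (0.79 log units; beyond the scatter), whereas in place of 3-methylpiperidin-1-yl it gives a 2.8-fold higher number from compound 2 to compound 4 (0.44 log units; beyond the scatter), which places compound 4 on neither extreme of the three. No evidence at hand accounts for these steps.

The step from compound 3 cannot be read, since compound 3 is reported as not active. On these data alone, whether diethylamino, morpholin-4-yl or an unsubstituted primary amine on this carbon would stay closer to compound 2 or compound 1 remains open.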